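Removing a methoxy group from the core of compound 1

This account rests on a few compounds, and the source may have more. Where it says the series, first, only, none or still open, it means among the compounds named here.

Among the compounds with values here, compound 1 `COc1ccc(-c2[nH]c3ccccc3c2/C=C(\C#N)S(=O)(=O)c2ccccc2)cc1` is one of three compounds measured in a functional assay on Hs-578T cells (Homo sapiens) for inhibition, read by sulforhodamine B assay, with a stated time of 48 h (a lower number here means a stronger inhibitor of growth, a higher number a weaker inhibitor of growth), and in that assay compound 1 gives 682 nM. It has the highest of the three numbers, but neither neighbour is far away. Compound 2 `COc1ccc(-c2[nH]c3ccc(OC)cc3c2/C=C(\C#N)S(=O)(=O)c2ccccc2)cc1` gives 538 nM in this assay, and compound 3 `COc1ccc(-c2[nH]c3ccc(OC)cc3c2C=C(C#N)C#N)cc1` gives 513 nM. The one step that links two of these compounds by a single change, a 1.3-fold lower number from compound 1 to compound 2 (0.10 log units; within the scatter), introduces a methoxy group on an aromatic carbon and stays within the scatter.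

Compound 4 `N#C/C(=C\c1c(-c2ccccc2)[nH]c2ccccc12)S(=O)(=O)c1ccccc1` has not yet been measured. It differs from compound 1 by hydrogen in place of methoxy on an aromatic carbon. The change sits on the same kind of atom as the change from compound 1 to compound 2, but on a different ring, so that measured step bears on it only loosely. What it does show is that adding or taking away a methoxy group on an aromatic carbon of this core produced no shift beyond the scatter. For compound 4 the expectation is therefore a step of about a 1.2-fold higher number from compound 1 to compound 4 (0.07 log units; within the scatter), which is no real change. The estimated value for compound 4 in this assay is 800 nM, with a range from 350 nM to 1800 nM.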

Compound 4, concentration for 50% growth inhibition: 23600 nM
Compound 4: middle estimate off by 30-fold (1.47 log units), on the low side; the whole stated range lies below it.
By their numbers in this assay, from the lowest: compounds 3, 2 and 1 (each within the scatter of the next); then compound 4.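

In this assay, replacing the 4-methoxyphenyl of compound 1 with phenyl gives a 35-fold higher number from compound 1 to compound 4 (1.54 log units; beyond the scatter), so the methoxy on this aromatic carbon, para to a large group, is tied to a large part of the growth inhibition seen with compound 1. The earlier step of a 1.3-fold lower number from compound 1 to compound 2 (0.10 log units; within the scatter) stays within the scatter, which shows that the two methoxy positions do not behave alike, even though both changes involve a methoxy group on an aromatic carbon of a six-membered aromatic ring of carbon only. A single methoxy group can thus be almost silent in one part of these molecules and matter greatly in another, yet nothing in hand explains why this step is so large.

The compounds shown do not tell whether the methoxy group is specifically needed at this position or whether another group there, such as hydroxyl, fluorine, ethoxy or an amine, would serve as well. They also leave open whether the same change would have a similar effect on compound 2 or compound 3, whose other groups differ from those of compound 1.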